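A few compounds are considered here, and "the series" means these few. Any claim that something is new, unique, unknown or untested is made for them only; others in the source may bear on it.

Compound 3 `c1coc(CNCCCNc2ccnc3cc(CC4CCCCC4)ccc23)c1` is one of three analogues sharing a core that carries an aminopropylamino side chain. In a physicochemical assay for acid dissociation, compound 3 gives 9.47, level at the digits shown with compound 1 `COc1cccc(CNCCCNc2ccnc3cc(-c4ccc(C(F)(F)F)cc4)ccc23)c1O`, which gives 9.47, and only slightly apart from compound 2 `COc1cccc(CNCCCNc2ccnc3cc(Oc4ccccc4)ccc23)c1O`, which gives 9.28; all three numbers lie within the usual scatter of one another. Within the data shown here, the single measured step, a number 0.19 log units lower from compound 1 to compound 2 (within the scatter), is within the scatter. Compound 4 `COc1cccc(CNCCCNc2ccnc3cc(CC4CCCCC4)ccc23)c1O` differs from compound 3 in one place: 2-hydroxy-3-methoxyphenyl in place of furan-2-yl on a saturated chain carbon bound to an amine nitrogen. Compounds 1 and 2 already carry the entering group and sit within the scatter of compound 3, so no shift beyond the scatter is expected, a step of a number 0.07 log units lower from compound 3 to compound 4 (within the scatter). Compound 4 is therefore estimated at 9.4, between 9.1 and 9.7.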

Compound 4, acid dissociation constant: 9.47
Compound 4: middle estimate off by 0.07 log units, on the low side, and the stated range covers the measured number.
By their numbers in this assay, from the lowest: compounds 2, 1, 3 and 4 (each within the scatter of the next).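

In this assay there is no change at the digits printed from compound 3 to compound 4 (within the scatter) when 2-hydroxy-3-methoxyphenyl stands in place of furan-2-yl on the saturated chain carbon bound to an amine nitrogen, so this exchange of rings, which adds a hydrogen-bond donor, leaves the reading unmoved. With the entering group in common, there is no change at the digits printed from compound 1 to compound 4 (within the scatter) and a number 0.19 log units higher from compound 2 to compound 4 (within the scatter) for the changes on the aromatic carbon, so neither of those steps stands out either. Nothing available offers an explanation for this. Going by these compounds, whether a carboxylic acid in place of either ring, or a longer chain in place of the aminopropylamino side chain, would move the number beyond the scatter stays open.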